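Vero cytotoxicity: carbamate to urea on the shared core

This account rests on a few compounds, and the source may have more. Where it says the series, first, only, none or still open, it means among the compounds named here.

Compound 1 `CCOCCOC(=O)Nc1cc2nc(C3CCCCC3)[nH]c2cc1N(C)C` is the starting point of this step. In an ADME assay on Vero cells (Chlorocebus sabaeus) for cytotoxicity, read by resazurin assay, with a stated time of 3 days (on this read-out higher numbers stand for weaker inhibition and lower numbers for stronger inhibition), compound 1 reaches only the assay limit, > 100 ug/mL. Compound 2 `O=C(Nc1cc2nc(C3CCCCC3)[nH]c2cc1N1CCCC1)c1ccccc1` in this assay likewise stops at the limit, > 100 ug/mL. Compound 3 `COCCOC(=O)Nc1cc2nc(C3CCCCC3)[nH]c2cc1N1CCCC1` in this assay also gives only the limit, > 100 ug/mL. Thus (the limit of > 100 ug/mL in this assay, at which 3 of the 3 values shown sit), and the one single-point step in the set, a step that the two limits leave unreadable from compound 2 to compound 3, runs between two limits and has no readable size. Compound 1 therefore stands at the limit, with no number separating it from compound 2 or compound 3.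

Compound 4 `CCCCNC(=O)Nc1cc2nc(C3CCCCC3)[nH]c2cc1N(C)C` differs from compound 1 in one place: butylamino in place of 2-ethoxyethoxy on a carbonyl carbon. Going by the values given here, no measured step bears on this change; every value shown is a limit, so no size of effect can be drawn from the series. No step beyond the scatter in this assay is expected, and the estimated step that the limit leaves unreadable from compound 1 to compound 4 is expected to be flat. Compound 4 is expected to return 150 ug/mL in this assay, within 50 ug/mL to 400 ug/mL, most likely again reported only as the limit.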

Compound 4, half-maximal inhibitory concentration: > 100 ug/mL
Compound 4 was reported as a limit; the forecaster's own chance of this, stated with the estimate: 85%; the middle value is on the limit's open side.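

No step can be read between compound 1 and compound 4, because both values are limits: the limit of > 100 ug/mL in this assay, at which 4 of the 4 values shown sit.

The compounds shown leave open whether any group on the carbonyl carbon of the shared core gives a readable value rather than a limit.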